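A Catechol Hydrazone Variant of the Aryl Urea Core

The source may report more compounds than this note shows. Statements on the series, on what has been measured and on what is new or still open speak of the compounds shown alone.

Measured so far:
compound 1 `CN(C)CCn1cnnc1-c1cc(Oc2ccc(NC(=O)N/N=C/c3cc(C(C)(C)C)cc(C(C)(C)C)c3O)cc2F)ccn1`: 520 nM
compound 2 `COc1ccc(/C=N/NC(=O)Nc2ccc(Oc3ccnc(-c4nncn4CCN(C)C)c3)c(F)c2)c(OC)c1OC`: 7650 nM
compound 3 `CN(C)CCn1cnnc1-c1cc(Oc2ccc(NC(=O)N/N=C/c3ccccc3O[N+](=O)[O-])cc2F)ccn1`: 7150 nM

In a functional assay on U-87MG ATCC cells (Homo sapiens) for cytotoxicity, read by MTT assay, with a stated time of 72 h (a higher number here means a weaker inhibitor, a lower number a stronger inhibitor), compound 3 gives 7150 nM, the second highest of the three numbers. Compound 2 stands nearest to it, and compound 1, with 520 nM, stands furthest away. Compound 4 `CN(C)CCn1cnnc1-c1cc(Oc2ccc(NC(=O)N/N=C/c3ccc(O)c(O)c3)cc2F)ccn1` differs from compound 3 at a single place: 3,4-dihydroxyphenyl in place of 2-(nitrooxy)phenyl on a carbon with a double bond to nitrogen. Going by the values given here, the one measured step at this place, a 1.1-fold lower number from compound 2 to compound 3 (0.03 log units; within the scatter), exchanged different groups and so gives no size for the present change. With only compound 3 to go on, the step of a 1.4-fold lower number from compound 3 to compound 4 (0.16 log units; within the scatter) is expected to stay within the scatter. Compound 4 is therefore estimated at 5000 nM, with a range from 1500 nM to 15000 nM.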

Compound 4, half-maximal inhibitory concentration: > 100000 nM
Compound 4: no number, only a limit; the forecaster's own chance of this, stated with the estimate: 5%; at least 20-fold (1.30 log units) between middle value and limit.
By their numbers in this assay, from the lowest: compound 1; then compounds 3 and 2 (each within the scatter of the next). At a limit, above all of these: compound 4.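

In this assay, compound 4 gives a limit and not a number: the limit of > 100000 nM in this assay, at which 1 of the 4 values shown sits. The earlier exchange of 2,3,4-trimethoxyphenyl for 2-(nitrooxy)phenyl had left the reading within the scatter, but this position proves sensitive to the group it carries, with 3,4-dihydroxyphenyl giving an at least 13-fold higher number from compound 3 to compound 4 (1.14 log units; beyond the scatter) and an at least 13-fold higher number from compound 2 to compound 4 (1.11 log units; beyond the scatter).

The compounds shown leave open whether this step depends on both hydroxyl groups of 3,4-dihydroxyphenyl. On these data alone, what a phenyl ring with a single hydroxyl, a methoxy pair, an amine or a carboxylic acid would give here also remains open.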